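Pyrimidine series: oxan-4-yl for isopropyl on the pyrazole nitrogen

The source may hold more compounds than are shown below. What is called first, only, known or untested is meant among the compounds shown, and "the series" means these compounds.

Measured so far:
compound 1 `CC(C)n1cc(Nc2ncc(C3CC3)c(NCCCNC(=O)C3CCC3)n2)cn1` gives 4 nM
compound 2 `O=C(NCCCNc1nc(Nc2cccnc2)ncc1C1CC1)C1CCC1` gives 13 nM
compound 3 `O=C(NCCCNc1nc(Nc2cccc(F)c2)ncc1Br)c1ccc(C(F)(F)F)cc1` gives 450 nM

All three numbers come from an assay on isolated protein for inhibition of serine/threonine-protein kinase TBK1 (Homo sapiens); on this read-out higher numbers stand for weaker inhibition and lower numbers for stronger inhibition. Compound 1 holds the lowest number of the three; compound 2 is nearest, and compound 3 is furthest away.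

The step under review is compound 1 to compound 4 `O=C(NCCCNc1nc(Nc2cnn(C3CCOCC3)c2)ncc1C1CC1)C1CCC1`: oxan-4-yl in place of isopropyl on an aromatic nitrogen. Among the measured compounds shown here, no measured step changes this substituent alone; the only single-change step, a 3.3-fold higher number from compound 1 to compound 2 (0.51 log units; beyond the scatter), swaps the whole ring that carries it and is modest. The pyrazole itself is therefore kept, so little movement in this assay is expected: a 1.3-fold higher number from compound 1 to compound 4 (0.10 log units; within the scatter).

Compound 4 is estimated at 5 nM, with a range of 2 nM to 15 nM.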

Compound 4, half-maximal inhibitory concentration: 2 nM
Compound 4: the middle estimate sits 2.5-fold (0.40 log units) above what was measured; measured number inside the range.
By their numbers in this assay, from the lowest: compounds 4 and 1 (each within the scatter of the next); then compound 2; then compound 3.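

Working from this assay, oxan-4-yl on the aromatic nitrogen of the five-membered aromatic ring can stand in for isopropyl with no change beyond the scatter (a 2.0-fold lower number from compound 1 to compound 4 (0.30 log units; within the scatter)). Among the compounds shown here, this position therefore accepts a larger substituent that brings a six-membered non-aromatic ring and a hydrogen-bond acceptor, which the earlier compounds, none of which varied this substituent alone, could not show. No measurement at hand accounts for this tolerance.

The compounds shown leave open whether the ring oxygen plays any part, which cyclohexyl would test. Also open, on these data alone, is whether piperidin-4-yl, with its ring amine, or a carboxylic acid on a longer chain would be accepted here as well.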